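The compounds below may be only part of what the source reports. "The series", "measured", "known", "first", "only" and "open" are said of these compounds alone.

Measured so far:
compound 1 `CCOC(=O)CN(Cc1ccccc1)c1nc(NCc2ccccc2)ncc1[N+](=O)[O-]` — > 100000 nM
compound 2 `COC(=O)CN(C)c1nc(NCc2ccccc2)ncc1[N+](=O)[O-]` — 85900 nM
compound 3 `CCOC(=O)CNc1nc(Nc2ccc(Cl)cc2)ncc1[N+](=O)[O-]` — > 100000 nM

In a functional assay on MCF7 cells (Homo sapiens) for antiproliferative activity, read by MTT assay, with a stated time of 48 h (a higher number here means a weaker inhibitor, a lower number a stronger inhibitor), compound 3 gives only a limit, > 100000 nM, and not a number. The same holds for compound 1, whose value is also a limit (the limit of > 100000 nM in this assay, at which 2 of the 3 values shown sit). Compound 2 gives a number in this assay, 85900 nM, which is the only one here.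

Compound 4 `CCOC(=O)CNc1nc(NCc2ccccc2)ncc1[N+](=O)[O-]` is not yet measured. It differs from compound 3 by one change: benzyl in place of 4-chlorophenyl on a nitrogen on an aromatic ring. Compounds 1 and 2 carry that benzylamino group too and remain weak, so no step beyond the scatter is expected from compound 3 to compound 4. Compound 4 is estimated at 90000 nM in this assay, in the range 40000 nM to 200000 nM, an expected step of an at least 1.1-fold lower number from compound 3 to compound 4 (0.04 log units; that floor lies within the scatter), with a fair chance that only a limit is again reported.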

Compound 4, half-maximal inhibitory concentration: 52400 nM
Estimate against measurement, compound 4: 1.7-fold (0.23 log units) above; the range from low to high includes it.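

In this assay, benzyl in place of 4-chlorophenyl on a nitrogen on an aromatic ring gives an at least 1.9-fold lower number from compound 3 to compound 4 (0.28 log units; that floor lies within the scatter), so this change yields a number where there was only a limit. Hydrogen in place of benzyl on a nitrogen on an aromatic ring gives an at least 1.9-fold lower number from compound 1 to compound 4 (0.28 log units; that floor lies within the scatter), and both of these floors lie within the scatter and rest on a limit: the limit of > 100000 nM in this assay, at which 2 of the 4 values shown sit. ((Ethoxycarbonyl)methyl)amino in place of ((methoxycarbonyl)methyl)(methyl)amino gives a 1.6-fold lower number from compound 2 to compound 4 (0.21 log units; within the scatter), which shows no real change.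

Going by these compounds, whether a phenethyl chain in place of benzyl, or a carboxylic acid in place of the ester, would move the value beyond the scatter stays open.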